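Removing the Methyl from the Pyrazole of Compound 1

The source may report more compounds than this note shows. Statements on the series, on what has been measured and on what is new or still open speak of the compounds shown alone.

Compound 1 `Cc1n[nH]cc1-c1cccc2c1CCC2c1ncc[nH]1` is the reference point of this small set. In a functional assay on CHO cells for agonist activity at Alpha-1A adrenergic receptor (Homo sapiens), read by FLIPR and calcium flux (on this read-out lower numbers stand for an effect already at smaller amounts and higher numbers for an effect only at larger amounts of compound), compound 1 gives 3 nM, the lowest number among the three measured compounds. Compound 2 `Cc1oncc1-c1cccc2c1CCC2c1ncc[nH]1` gives 111 nM and compound 3 `c1cc(-c2nccs2)c2c(c1)C(c1ncc[nH]1)CC2` gives 426 nM; the steps of a 37-fold higher number from compound 1 to compound 2 (1.57 log units; beyond the scatter) and a 140-fold higher number from compound 1 to compound 3 (2.15 log units; beyond the scatter) are both large, and the step of a 3.8-fold higher number from compound 2 to compound 3 (0.58 log units; beyond the scatter) is modest. All three measured steps exchange one five-membered heteroaryl ring for another; none of them removes a substituent from a ring that is otherwise kept.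

Compound 4 `c1cc(-c2cn[nH]c2)c2c(c1)C(c1ncc[nH]1)CC2` differs from compound 1 by hydrogen in place of methyl on an aromatic carbon, the same difference read one bond further out being 3-methyl-1H-pyrazol-4-yl to 1H-pyrazol-4-yl. Among the compounds with values here, no measured step bears directly on this change. The measured steps show that the identity of this ring matters greatly, so a change within it is expected to register, but a step smaller than the ring exchanges is expected, towards a higher number: a 3.3-fold higher number from compound 1 to compound 4 (0.52 log units; beyond the scatter). Compound 4 is therefore estimated at 10 nM, within a range from 3 nM to 40 nM.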

Compound 4, half-maximal effective concentration: 14 nM
Compound 4: the middle estimate sits 1.4-fold (0.15 log units) below what was measured; the range from low to high includes it.
By their numbers in this assay, from the lowest: compound 1; then compound 4; then compound 2; then compound 3.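

Here the methyl is the only thing that changes, and its loss gives a 4.7-fold higher number from compound 1 to compound 4 (0.67 log units; beyond the scatter), a modest step and smaller than either ring exchange away from the pyrazole of the reference compound. The ring itself still counts for more than the methyl in this set: the 1H-pyrazol-4-yl group, though it carries no methyl, gives a 7.9-fold lower number from compound 2 to compound 4 (0.90 log units; beyond the scatter), a modest step against a ring that keeps one, and a 30-fold lower number from compound 3 to compound 4 (1.48 log units; beyond the scatter), a large step against the 1,3-thiazol-2-yl group. No evidence is at hand on why the methyl contributes this much.

The compounds shown leave open how a longer chain such as ethyl, or an amine, would read on this carbon. They also leave open whether the methyl on the ring of compound 2 counts for as much as the one on the pyrazole.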